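The compounds below may be only part of what the source reports. "The series", "measured", "known", "first", "only" and "open" are said of these compounds alone.

Compound 1 `OCCCC(F)CF` stands lowest of the two compounds measured in a physicochemical assay for lipophilicity, read by NMR; a higher number here means a more lipophilic compound, a lower number a more polar compound: compound 1 gives 0.11, whereas compound 2 `CC(F)(F)CCCO` gives 0.71, a gap beyond the scatter. Compound 3 `OCCC(F)CF` differs from compound 1 by hydroxy in place of hydroxymethyl on a saturated chain carbon, three bonds along the chain from a fluorine atom. Within the data shown here, no step between two measured compounds covers this change, so its size cannot be read from the series. Losing one chain carbon is expected to lower the partition coefficient, a step of a number 0.46 log units lower from compound 1 to compound 3 (beyond the scatter), beyond the scatter. Compound 3 is therefore estimated at -0.35, within -0.85 to 0.15.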

Compound 3, partition coefficient: -0.12
Beside the measured number, compound 3's estimate is 0.23 log units below it; measured number inside the range.
By their numbers in this assay, from the lowest: compounds 3 and 1 (each within the scatter of the next); then compound 2.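

Hydroxy in place of hydroxymethyl on a saturated chain carbon, three bonds along the chain from a fluorine atom, gives in this assay a number 0.23 log units lower from compound 1 to compound 3 (within the scatter). Among these compounds, this is the first step read, and at this position the change leaves the two compounds unresolved by this measurement. Nothing on hand gives a reason for this result.

Open, as far as these compounds go, is whether a longer chain, or an amine in place of the hydroxy, would also stay within the scatter of compound 1 in this assay. Also open, from the compounds shown here alone, is whether the same change on the core of compound 2 gives a step of similar size.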